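Pyrazole series: methoxy to hydroxy on the chlorophenyl ring

The source may report more compounds than this note shows. Statements on the series, on what has been measured and on what is new or still open speak of the compounds shown alone.

Measured so far in a functional assay on NCI-H23 cells (Homo sapiens) for inhibition, read by sulforhodamine B assay, with a stated time of 48 h; on this read-out lower numbers stand for stronger inhibition of growth and higher numbers for weaker inhibition of growth:
compound 1 `COc1cc(-c2nn(-c3cccc(NC(=O)c4cccc(C(F)(F)F)c4)c3)cc2-c2ccncc2)ccc1Cl` gives 32500 nM
compound 2 `COc1cc(-c2nn(-c3cccc(NC(=O)Nc4cccc(C(F)(F)F)c4)c3)cc2-c2ccncc2)ccc1Cl` gives 3410 nM
compound 3 `COc1cc(-c2nn(-c3cccc(NC(=O)Nc4ccc(Cl)c(C(F)(F)F)c4)c3)cc2-c2ccncc2)ccc1Cl` gives 8030 nM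

Compound 3 holds the second highest of the three numbers, as the steps of a 4.0-fold lower number from compound 1 to compound 3 (0.61 log units; beyond the scatter) and a 2.4-fold higher number from compound 2 to compound 3 (0.37 log units; beyond the scatter) show.

Compound 4 `O=C(Nc1cccc(-n2cc(-c3ccncc3)c(-c3ccc(Cl)c(O)c3)n2)c1)Nc1ccc(Cl)c(C(F)(F)F)c1` differs from compound 3 by hydrogen in place of methyl on an oxygen on an aromatic ring. Among the measured compounds shown here, none of the measured steps touches this oxygen; all three concern the amide or urea side. For the measured compounds named here, there is therefore no measured step that bears on the change, and no direction can be read from the series. The number for compound 4 is expected to sit close to compound 3, with a 1.0-fold lower number from compound 3 to compound 4 (0.00 log units; within the scatter) as the estimated step, and the uncertainty is correspondingly wide. Compound 4 is thus estimated at 8000 nM in this assay, within 2500 nM to 25000 nM.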

Compound 4, concentration for total growth inhibition: 3330 nM
Estimate against measurement, compound 4: 2.4-fold (0.38 log units) above; low and high end bracket the measured number.
By their numbers in this assay, from the lowest: compounds 4 and 2 (each within the scatter of the next); then compound 3; then compound 1.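

Among the compounds shown here, on this assay the change from methoxy to hydroxy gives a 2.4-fold lower number from compound 3 to compound 4 (0.38 log units; beyond the scatter) and so shows that this oxygen, untouched by the earlier steps, affects the read-out. For the compounds shown here, it is the first measured change on the chlorophenyl side, and here the free hydroxy goes with the stronger inhibition of growth. No measured evidence accounts for the shift.

On these data alone, whether the same change holds with the urea side of compound 2 remains open. Also open, as far as these compounds go, is how an ethoxy group or an amine would compare at this position.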